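Swapping Propyl for Chloro on a Weak Inhibitor

The source may report more compounds than this note shows. Statements on the series, on what has been measured and on what is new or still open speak of the compounds shown alone.

In a functional assay for inhibition, with Rattus norvegicus as the target (a higher number here means a weaker inhibitor, a lower number a stronger inhibitor), compound 3 `CCCc1cc(C#N)ccc1/N=c1\c(O)c(O)\c1=N/[C@H](C)C(C)(C)C` gives 23100 nM as the highest of the three measured numbers. Compound 1 `CC(C)(C)/N=c1\c(O)c(O)\c1=N/c1cccnc1` gives 2800 nM there, and compound 2 `CC(C)(C)/N=c1\c(O)c(O)\c1=N/c1cccnc1Cl` gives 1770 nM there too. Compound 4 `C[C@@H](/N=c1\c(O)c(O)\c1=N/c1ccc(C#N)cc1Cl)C(C)(C)C` has chloro in place of propyl on an aromatic carbon and is still unmeasured. For the measured compounds named here, the only measured step involving chloro is a 1.6-fold lower number from compound 1 to compound 2 (0.20 log units; within the scatter) and it replaced hydrogen rather than propyl, so it is a loose guide. Going by the values given here, no measured step removes propyl. Compound 2, which carries chloro, stands at 1770 nM so a lower number is expected, with wide uncertainty. The expected change is a 5.8-fold lower number from compound 3 to compound 4 (0.76 log units; beyond the scatter) in this assay on this thin evidence. Compound 4 is estimated at 4000 nM with an expected range from 500 nM to 25000 nM for now.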

Compound 4, half-maximal inhibitory concentration: 41 nM
Compound 4: the middle estimate sits 98-fold (1.99 log units) above what was measured, and the stated range ends above it.
By their numbers in this assay, from the lowest: compound 4; then compounds 2 and 1 (each within the scatter of the next); then compound 3.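

On this aromatic carbon, ortho to a large group and meta to a cyano group, a single swap changes the result greatly: in this assay, chloro in place of propyl gives a very large step (a 560-fold lower number from compound 3 to compound 4 (2.75 log units; beyond the scatter)). The earlier chloro step (a 1.6-fold lower number from compound 1 to compound 2 (0.20 log units; within the scatter)) replaced hydrogen in a different pair of compounds and gave no sign of a change this size. Nothing available explains the size of this step.

On these data alone, whether the gain comes from adding chloro or from losing propyl stays open. Hydrogen, methyl or fluoro on this carbon could help separate the two.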